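Series notes: the step from compound 1 to compound 4

This account rests on a few compounds, and the source may have more. Where it says the series, first, only, none or still open, it means among the compounds named here.

In an assay for inhibition of Nicotinamide phosphoribosyltransferase (Homo sapiens), read by mass spectrometry, with stated times of 15 min and 30 min (a lower number here means a stronger inhibitor, a higher number a weaker inhibitor), compound 1 `O=C(NCc1ccc(S(=O)(=O)c2ccccc2)cc1)c1cc2ncccc2s1` gives 400 nM, the highest number of the three measured. Compound 2 `O=C(NCc1ccc(S(=O)(=O)N2CCCCC2)cc1)c1cc2cnccc2s1` gives 150 nM and compound 3 `O=C(NCc1ccc(S(=O)(=O)N2CCCCC2)cc1)c1cnc2nccn2c1` gives 3 nM. Among the measured compounds shown here, the only measured step that changes the part attached to the carbonyl carbon is a 50-fold lower number from compound 2 to compound 3 (1.70 log units; beyond the scatter), which shows that this position carries most of the movement seen so far in this assay.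

Compound 4 `O=C(NCc1ccc(S(=O)(=O)c2ccccc2)cc1)c1c[nH]c2ccncc12` differs from compound 1 by a group of 9 heavy atoms (7 carbon, 2 nitrogen; one five-membered aromatic ring with 1 hetero atom, one six-membered aromatic ring with 1 hetero atom) in place of a group of 9 heavy atoms (7 carbon, 1 nitrogen, 1 sulfur; one five-membered aromatic ring with 1 hetero atom, one six-membered aromatic ring with 1 hetero atom), on a carbonyl carbon. This is again a swap of the whole bicycle on the carbonyl carbon, but the group that enters is not the one that entered in the step from compound 2 to compound 3, so that step sets only the scale of what such a swap can do, not its size here. A lower number in this assay is expected, beyond the scatter but short of the measured step, with wide uncertainty. Compound 4 is expected to give 100 nM, in the range 20 nM to 600 nM, meaning an expected step of a 4.0-fold lower number from compound 1 to compound 4 (0.60 log units; beyond the scatter).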

Compound 4, half-maximal inhibitory concentration: 1900 nM
Beside the measured number, compound 4's estimate is 19-fold (1.28 log units) below it; measured number outside the range, above it.
By their numbers in this assay, from the lowest: compound 3; then compound 2; then compound 1; then compound 4.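

In this assay, a swap of the whole bicycle on the carbonyl carbon can also raise the number: a 4.8-fold higher number from compound 1 to compound 4 (0.68 log units; beyond the scatter), against a 50-fold lower number from compound 2 to compound 3 (1.70 log units; beyond the scatter), although these two steps stand on different remainders of the molecule. The group that leaves and the group that enters match in heavy-atom count and in ring sizes, and differ in sulfur against a second nitrogen and in their hydrogen-bond donor and acceptor counts, so matching ring sizes alone do not hold the number steady at this place. Nothing available here accounts for the rise.

Going by these compounds, whether the group that enters in compound 3 would also lower the number on the remainder of compound 1 stays open. Also open, on these data alone, is what an amine or a carboxylic acid on the bicycle of compound 4 would give.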